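A few compounds are considered here, and "the series" means these few. Any claim that something is new, unique, unknown or untested is made for them only; others in the source may bear on it.

Measured so far:
Compound 1 `N#C/C(=C\c1ccc(Cl)cc1)C(=O)c1ccc[nH]1`: in a functional assay on SW480 cells (Homo sapiens) for inhibition, read by MTT assay, with a stated time of 72 h (on this read-out lower numbers stand for stronger inhibition of growth and higher numbers for weaker inhibition of growth), compound 1 gives 34000 nM.
Compound 2 `N#C/C(=C\c1ccc[nH]1)C(=O)NCc1ccc(Cl)c(Cl)c1`: compound 2 reaches only the limit > 50000 nM in this assay.
Compound 3 `COc1ccc(CNC(=O)/C(C#N)=C/c2ccco2)cc1`: compound 3 gives 31000 nM in this assay.

Compound 3 is one of two compounds with a number rather than a limit, and compound 1 sits within the usual scatter of it, so the two cannot be told apart (the limit of > 50000 nM in this assay, at which 1 of the 3 values shown sits). Compound 4 `COc1ccc(CNC(=O)/C(C#N)=C/c2ccc(Cl)o2)cc1` differs from compound 3 by the change (chloro in place of hydrogen on an aromatic carbon), that is, chloro in place of hydrogen on an aromatic carbon. For the measured compounds named here, no measured pair shows what such a change does in this assay, so the expected step from compound 3 to compound 4 is small, likely within the scatter, with a lean toward a lower number, estimated at a 1.6-fold lower number from compound 3 to compound 4 (0.19 log units; within the scatter). Compound 4 is thus expected to give about 20000 nM, in the range 6000 nM to 60000 nM.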

Compound 4, concentration for 50% growth inhibition: 13000 nM
Compound 4: the middle estimate sits 1.5-fold (0.19 log units) above what was measured; measured number inside the range.
By their numbers in this assay, from the lowest: compound 4; then compounds 3 and 1 (each within the scatter of the next). At a limit, above all of these: compound 2.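

In this assay, for the compounds shown here, the change from furan-2-yl to 5-chlorofuran-2-yl gives a 2.4-fold lower number from compound 3 to compound 4 (0.38 log units; beyond the scatter) and forms the only one-place pair. Going by these compounds alone, this is the first sign that growth inhibition responds to substitution at this aromatic carbon next to the ring oxygen. Nothing measured here accounts for the step.

Still open, as far as these compounds go, is whether the step belongs to chloro alone or would also follow from bromo, methyl or an amine on the same carbon. Also open, from the compounds shown here alone, is whether it carries over to other amide substituents.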